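This account rests on a few compounds, and the source may have more. Where it says the series, first, only, none or still open, it means among the compounds named here.

Compound 1, `CCCOC(=O)C1=C(C)NC(=O)NC1c1cccs1`, is a small ester-bearing compound built on a shared core. In an assay on membranes from CHO cells for displacement of a labelled ligand from adenosine receptor A1 (Homo sapiens), read by scintillation counting, with a stated time of 60 min, tested at 1 uM (on this read-out higher numbers stand for more inhibition at the one concentration tested (going by the name of the read-out) and lower numbers for less inhibition), compound 1 gives 43%. Compound 2, `CC1=C(C(=O)OCC(C)C)C(c2cccs2)NC(=O)N1`, differs from it by one change: methyl in place of hydrogen on a saturated chain carbon bound to two saturated chain carbons. In this assay compound 2 gives 25%, and the step of a number 18 percentage points lower from compound 1 to compound 2 (beyond the scatter) shows this change costs some inhibition. Compound 3, `CCCOC(=O)C1=C(C)N(C)C(=O)NC1c1ccoc1`, has a different core; how its core differs from that of compound 1 is not broken down here. In this assay compound 3 gives 1%, the lowest of the three numbers. Compound 4, `CC1=C(C(=O)OCC(C)C)C(c2ccoc2)NC(=O)N1C`, relates to compound 3 by the same change: methyl in place of hydrogen on a saturated chain carbon bound to two saturated chain carbons. Because a number 18 percentage points lower from compound 1 to compound 2 (beyond the scatter) pointed downward and compound 3 already sits near the floor of the read-out, the step of no change at the digits printed from compound 3 to compound 4 (within the scatter) is expected to be small. Compound 4 is therefore estimated at 1%.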

Compound 4, a percentage reported as inhibition, at one concentration (the size of the read-out at that concentration, not a potency): 4%
Compound 4: middle estimate off by 3 percentage points, on the low side; measured number inside the range.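

The new result is a number 3 percentage points higher from compound 3 to compound 4 (within the scatter), so in this assay this change leaves compound 3 and compound 4 indistinguishable. Set beside the earlier step, the same change does not give the same result on the two cores, so its outcome on one core cannot simply be assumed for the other: the same change on two cores in this assay, a number 18 percentage points lower (beyond the scatter) from compound 1 to compound 2 and a number 3 percentage points higher (within the scatter) from compound 3 to compound 4, 21 percentage points apart, beyond the scatter of two such steps This does not show why the two steps differ, and with compound 3 at only 1%, a drop would have little room to appear, so one pair per core cannot separate a true core effect from a low starting number.

The compounds shown leave open how a longer chain, such as butoxy in place of propoxy, would read on either core. They also leave open which of the two outcomes a further core would follow.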